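The source may hold more compounds than are shown below. What is called first, only, known or untested is meant among the compounds shown, and "the series" means these compounds.

Compound 1 `C[C@H](c1ccc(-c2ccccc2-c2nc(=O)o[nH]2)cc1)N(CC1CC1)c1nc2c(C(=O)O)cccc2o1` gives 11 nM in a functional assay on CAL1 cells for inhibition of chemerin-like receptor 1 (Homo sapiens), with a stated time of 45 min; a higher number here means a weaker inhibitor, a lower number a stronger inhibitor.
Compound 2 `CCCCN(c1nc2c(NS(C)(=O)=O)cccc2o1)[C@H](C)c1ccc(-c2ccccc2-c2nnn[nH]2)cc1` gives 14 nM in this assay.

Of the compounds shown here, two have been measured here, and they share a common core with a sidechain and a biphenyl arm carrying an acidic ring. Compound 1 shows the lowest of the two numbers; compound 2 lies closest to it, and the gap between them falls within the scatter of repeated measurements, so the two cannot be ranked against each other.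

Compound 3 `C[C@H](c1ccc(-c2cc(F)ccc2-c2nc(=O)o[nH]2)cc1)N(CC1CC1)c1nc2c(C(=O)O)cccc2o1` is the untested partner of compound 1. Going by the values given here, the single change is fluoro in place of hydrogen on an aromatic carbon; the place is a six-membered aromatic ring of carbon only, meta to a large group and para to a group of 6 heavy atoms. Among the compounds with values here, no pair of measured compounds differs by such a change, so there is no measured step to lean on. With a single added fluorine and no other change, the expected step from compound 1 to compound 3 in this assay is a 1.1-fold higher number from compound 1 to compound 3 (0.04 log units; within the scatter), in neither direction beyond the scatter. Compound 3 is therefore estimated at 12 nM, with a range from 5 nM to 30 nM.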

Compound 3, half-maximal inhibitory concentration: 2.3 nM
Compound 3: middle estimate off by 5.2-fold (0.72 log units), on the high side, and the stated range ends above it.
By their numbers in this assay, from the lowest: compound 3; then compounds 1 and 2 (each within the scatter of the next).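

In this assay, replacing one hydrogen with fluoro gives a 4.8-fold lower number from compound 1 to compound 3 (0.68 log units; beyond the scatter), so this aromatic carbon, meta to a large group and para to a group of 6 heavy atoms, is a place where even one added atom can shift the number beyond the scatter. Going by these compounds alone, this is the first measured step between compounds that differ in only one place, and it shows that the change points toward stronger inhibition in this setting, although one pair cannot establish a general rule for the series. No measurement shown here explains the lower number, so the data record the size and direction of the step but not its cause.

The compounds shown leave open whether the effect belongs to fluoro itself or would also appear with a chloro, methyl or methoxy group at this same place. They also leave open whether fluoro would have a similar effect at other carbons of this ring, or whether the same change would lower the number when made on compound 2.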